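The compounds below may be only part of what the source reports. "The series", "measured", "known", "first", "only" and "open" are said of these compounds alone.

Measured compounds:
compound 1, `COc1cc2cc(Oc3ccc(NC(=O)Nc4ccccc4)cc3)c(C)nc2cc1OC`: 65.9%
compound 2, `COc1cc2cc(Oc3ccc(NC(=O)Nc4cccc(C(F)(F)F)c4)cc3)c(C)nc2cc1OC`: 11.3%

Within the data shown here, in a functional assay on UO-31 cells (Homo sapiens) for inhibition, read by sulforhodamine B assay, with a stated time of 48 h, tested at 10 uM (on this read-out higher numbers stand for a weaker effect at the one concentration tested and lower numbers for a stronger effect), compound 1 stands highest of the two numbers recorded; its nearest neighbour is compound 2, and the gap between them is the only measured step, a number 54.6 percentage points lower from compound 1 to compound 2 (beyond the scatter). That step brings trifluoromethyl in place of hydrogen on an aromatic carbon.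

Compound 3, `COc1cc2cc(Oc3ccc(NC(=O)Nc4ccc(Cl)c(C(F)(F)F)c4)cc3)c(C)nc2cc1OC`, is still to be measured. It differs from compound 1 by 4-chloro-3-(trifluoromethyl)phenyl in place of phenyl on an amide-type nitrogen. The entering group carries the same trifluoromethyl that enters in compound 2, with a chlorine added on the same ring, so the step from compound 1 to compound 2 bears directly on it. That step was large and downward, beyond the scatter, and a step of comparable size and direction is expected here.

Compound 3 is therefore estimated to give 12% in this assay, within a range of 0% to 35%, which means an expected step of a number 53.9 percentage points lower from compound 1 to compound 3 (beyond the scatter).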

Compound 3, a percentage reported as activity, at one concentration (the size of the read-out at that concentration, not a potency): -45.1%
Compound 3: middle estimate off by 57.1 percentage points, on the high side; measured number outside the range, below it.
By their numbers in this assay, from the lowest: compound 3; then compound 2; then compound 1.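

In this assay, adding chloro to the ring that already carries trifluoromethyl moves the read-out much further, with a step of a number 56.4 percentage points lower from compound 2 to compound 3 (beyond the scatter), so trifluoromethyl alone had not exhausted what this aryl group can do. The full change, 4-chloro-3-(trifluoromethyl)phenyl in place of phenyl on the amide-type nitrogen, amounts to a number 111 percentage points lower from compound 1 to compound 3 (beyond the scatter), and compound 3 at -45.1% is the only one of the three with a number below zero. The read-out at this place can therefore go well past the level of compound 2. Nothing available accounts for the added effect of chloro.

These compounds do not tell whether chloro on the phenyl ring without trifluoromethyl would lower the number at all. As far as these compounds go, it also stays open whether a methoxy group or an amine in place of the chloro would keep the effect.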